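Methyl Added to the Methylsulfonyl Analogue

The compounds below may be only part of what the source reports. "The series", "measured", "known", "first", "only" and "open" are said of these compounds alone.

Among the compounds with values here, compound 3 `COc1ccc(S(C)(=O)=O)cc1C(=O)Nc1cccc(-c2nncn2C(C)C)n1` gives 3% in an assay for inhibition of RAC-alpha serine/threonine-protein kinase (Homo sapiens), tested at 1 uM (a higher number here means more inhibition at the concentration tested (going by the name of the read-out), a lower number less inhibition), the lowest of the three numbers measured so far, though it sits within the scatter of compound 2 `COc1cc(C)c(S(N)(=O)=O)cc1C(=O)Nc1cccc(-c2nncn2C(C)C)n1`, which gives 6%, and of compound 1 `COc1ccc(S(N)(=O)=O)cc1C(=O)Nc1cccc(-c2nncn2C(C)C)n1`, which gives 8%. Compound 4 `COc1cc(C)c(S(C)(=O)=O)cc1C(=O)Nc1cccc(-c2nncn2C(C)C)n1` differs from compound 3 by methyl in place of hydrogen on an aromatic carbon. Within the data shown here, two measured steps bear on this change. The same exchange gave a number 2 percentage points lower from compound 1 to compound 2 (within the scatter), and the exchange on the sulfonyl sulfur gave a number 5 percentage points lower from compound 1 to compound 3 (within the scatter). Neither moved the read-out beyond the scatter, so no step beyond the scatter is expected in this assay for compound 4. Compound 4 is therefore estimated at 2%, in a range from -6% to 12%. The expected step is a number 1 percentage points lower from compound 3 to compound 4 (within the scatter).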

Compound 4, a percentage reported as inhibition, at one concentration (the size of the read-out at that concentration, not a potency): 1%
Compound 4: the middle estimate sits 1 percentage points above what was measured, within the range that was stated.
By their numbers in this assay, from the lowest: compounds 4, 3, 2 and 1 (each within the scatter of the next).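

In this assay, methyl in place of hydrogen on the aromatic carbon ortho to a methylsulfonyl group gives a number 2 percentage points lower from compound 3 to compound 4 (within the scatter), so this change now reads alike on two cores: the same change on two cores in this assay, a number 2 percentage points lower (within the scatter) from compound 1 to compound 2 and a number 2 percentage points lower (within the scatter) from compound 3 to compound 4, 0 percentage points apart, within the scatter of two such steps

With that aromatic methyl present, methyl in place of amino on the sulfonyl sulfur gives a number 5 percentage points lower from compound 2 to compound 4 (within the scatter), and this exchange also reads alike on two cores: the same change on two cores in this assay, a number 5 percentage points lower (within the scatter) from compound 1 to compound 3 and a number 5 percentage points lower (within the scatter) from compound 2 to compound 4, 0 percentage points apart, within the scatter of two such steps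

Neither change has yet moved this read-out beyond the scatter, at either core.

From the compounds shown here alone, whether an amine or a longer chain in place of the aromatic methyl would do so remains open.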